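Methyl for hydrogen on the chain: a small step repeated

The source may hold more compounds than are shown below. What is called first, only, known or untested is meant among the compounds shown, and "the series" means these compounds.

Measured so far:
Compound 1, `CCC(=O)N[C@@H]1CCCc2c1cncc2N1C(=O)c2ccc(Cl)cc2[C@@H]1C`, gives 6 nM in an assay on cells for inhibition of cytochrome P450 11B2, mitochondrial (Homo sapiens), read by HTRF; on this read-out higher numbers stand for weaker inhibition and lower numbers for stronger inhibition.
Compound 2, `CCC1c2cc(Cl)ccc2C(=O)N1c1cccnc1`, gives 121 nM in this assay.
Compound 3, `CC1c2cc(Cl)ccc2C(=O)N1c1cccnc1`, gives 123 nM in this assay.

Compound 1 stands lowest of the three in this assay, with compound 2 and compound 3 well beyond the scatter above it. Compound 2 and compound 3 share a core and differ in one place only: methyl in place of hydrogen on a saturated chain carbon bound to a saturated ring carbon. That step, a 1.0-fold lower number from compound 3 to compound 2 (0.01 log units; within the scatter), left the read-out where it was. Compound 1 has a different core from compound 3; the difference between the two cores is not broken down here.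

Compound 4, `CCC(=O)N[C@@H]1CCCc2c1cncc2N1C(=O)c2ccc(Cl)cc2[C@@H]1CC`, has not yet been measured in this assay. It differs from compound 1 in one place: methyl in place of hydrogen on a saturated chain carbon bound to a saturated ring carbon. The place is the same as in the change from compound 3 to compound 2, so the two changes are the same. Because a 1.0-fold lower number from compound 3 to compound 2 (0.01 log units; within the scatter) showed no movement on the other core, the step from compound 1 to compound 4 is expected to be about as small, no change at the digits printed from compound 1 to compound 4 (within the scatter). The expectation rests on that single earlier pair only, and the two cores are not the same, so the range is kept wide. Compound 4 is estimated at 6 nM in this assay, between 2.5 nM and 15 nM.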

Compound 4, half-maximal inhibitory concentration: 12 nM
Beside the measured number, compound 4's estimate is 2.0-fold (0.30 log units) below it; the measured number falls inside the stated range.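

In this assay, putting methyl in place of hydrogen on the core of compound 1 gave a 2.0-fold higher number from compound 1 to compound 4 (0.30 log units; within the scatter) and so stayed inside the usual spread of repeated measurements. Set beside the earlier pair, the methyl to ethyl change reads alike on the two cores, with no difference that can be told apart from measurement spread: the same change on two cores in this assay, a 1.0-fold lower number (0.01 log units; within the scatter) from compound 3 to compound 2 and a 2.0-fold higher number (0.30 log units; within the scatter) from compound 1 to compound 4, 2.0-fold (0.31 log units) apart, within the scatter of two such steps. Among the compounds shown here, this shows that on these two cores the change left the read-out within the scatter, so the earlier step was a fair guide here, but it rests on only two pairs and does not show that the same would hold on a third core, nor does it explain why the read-out stayed within the scatter.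

The compounds shown leave open how far this tolerance extends: a longer chain such as propyl, a cyclopropyl ring, an amine or a carboxylic acid in the same place, on a saturated chain carbon bound to a saturated ring carbon, could give a very different number. They also leave open whether the pattern seen here would carry over to any read-out other than this one.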